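Fluoro for chloro on the fused ring of compound 2

The compounds below may be only part of what the source reports. "The series", "measured", "known", "first", "only" and "open" are said of these compounds alone.

Compound 1 `CS(=O)(=O)c1ccc(Nc2ncc(F)c(Nc3nc4ccccc4s3)n2)cc1`: 2830 nM
Compound 2 `Cc1cnc(Nc2ccc(S(C)(=O)=O)cc2)nc1Nc1nc2ccc(Cl)cc2s1`: 13400 nM

Of the compounds shown here, two have been tested in a functional assay on PC-3 cells (Homo sapiens) for antiproliferative activity, read by MTT assay, with a stated time of 48 h; a higher number here means a weaker inhibitor, a lower number a stronger inhibitor. Compound 1 gives 2830 nM, while compound 2 gives 13400 nM, the higher of the two numbers, with compound 1 lying well beyond the scatter of it. Among the compounds with values here, the two compounds differ in more than one place, so no single step between them can be read from their values.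

Compound 3 `Cc1cnc(Nc2ccc(S(C)(=O)=O)cc2)nc1Nc1nc2ccc(F)cc2s1` is not yet measured. It arises from compound 2 by a single change: fluoro in place of chloro on an aromatic carbon. No step of this kind has been measured among the compounds shown, so its size and direction are unknown. Because compound 2 stands at 13400 nM, the expectation for compound 3 is a modest change, likely within or just beyond the scatter, with a slight lean toward a lower number, giving an estimated step of a 1.7-fold lower number from compound 2 to compound 3 (0.22 log units; within the scatter). Compound 3 is estimated at 8000 nM in this assay, within a range of 3000 nM to 25000 nM.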

Compound 3, half-maximal inhibitory concentration: > 50000 nM
Compound 3 was reported as a limit; the forecaster's own chance of this, stated with the estimate: 5%; at least 6.2-fold (0.79 log units) between middle value and limit.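

In this assay compound 3 stands at > 50000 nM, which is a limit of the assay and not a number: the limit of > 50000 nM in this assay, at which 1 of the 3 values shown sits.

Fluoro in place of chloro on this aromatic carbon is the first single change that can be read among these compounds, and it gives an at least 3.7-fold higher number from compound 2 to compound 3 (0.57 log units; beyond the scatter). The position therefore responds to the exchange of one halogen for another, even though the count of hydrogen-bond donors and acceptors stays the same and no net charge enters, and only the chloro compound of this pair gives a measured number.

The compounds shown leave open how far past the limit compound 3 lies and whether a methoxy group or an amine on this carbon would give a lower number than chloro. Compound 1 differs from compound 2 and compound 3 in more than one place, so it cannot settle either question.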